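Glycyl Carbonyl in Place of Methyl on the Amine Nitrogen

The source may report more compounds than this note shows. Statements on the series, on what has been measured and on what is new or still open speak of the compounds shown alone.

Measured so far in an assay on HEK293 cells for displacement of a labelled ligand from Melanocortin receptor 4 (Homo sapiens); a higher number here means a weaker inhibitor, a lower number a stronger inhibitor:
compound 1, `CCC(C)[C@H](NCCN)c1cc(C(F)(F)F)ccc1N1CCN(C(=O)CCc2ccc(Cl)cc2Cl)CC1`, gives 56 nM
compound 2, `CCC(C)[C@H](NC[C@H]1CCCN1)c1cc(C(F)(F)F)ccc1N1CCN(C(=O)CCc2ccc(Cl)cc2Cl)CC1`, gives 110 nM
compound 3, `CN[C@@H](CC(C)C)c1cc(C(F)(F)F)ccc1N1CCN(C(=O)CCc2ccc(Cl)cc2Cl)CC1`, gives 1900 nM

Compound 3 stands highest of the three numbers in this assay, far from both others. Compound 4, `CC(C)C[C@H](NC(=O)CN)c1cc(C(F)(F)F)ccc1N1CCN(C(=O)CCc2ccc(Cl)cc2Cl)CC1`, has not yet been measured. It differs from compound 3 in one place: (aminomethyl)carbonyl in place of methyl on an amine nitrogen.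

Going by the values given here, two measured steps bear on this. Both a 34-fold higher number from compound 1 to compound 3 (1.53 log units; beyond the scatter) and a 17-fold higher number from compound 2 to compound 3 (1.24 log units; beyond the scatter) show that a side chain carrying a further nitrogen, in place of the bare methyl, gives a much lower number. Among the compounds with values here, compound 4 again carries a further nitrogen on its chain, here as the aminomethyl of the entering group, but the group is joined through a carbonyl, and no measured pair tests such an amide. The step is therefore expected to fall short of those two steps. Compound 4 is expected to give 450 nM, with a range from 120 nM to 1700 nM, a step of a 4.2-fold lower number from compound 3 to compound 4 (0.63 log units; beyond the scatter).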

Compound 4, inhibition constant: 19 nM
The estimate for compound 4 lay 24-fold (1.37 log units) above the measured number; the measured number lies below the stated range.
By their numbers in this assay, from the lowest: compound 4; then compounds 1 and 2 (each within the scatter of the next); then compound 3.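

Measured in this assay the amine nitrogen on the saturated chain carbon accepts an amide linkage, and (aminomethyl)carbonyl in place of methyl brings the largest change seen so far (a 100-fold lower number from compound 3 to compound 4 (2.00 log units; beyond the scatter)). A further nitrogen joined through a carbonyl therefore does not lose the gain seen with the earlier amine side chains, and the number falls lower still (a 2.9-fold lower number from compound 1 to compound 4 (0.47 log units; beyond the scatter)) and (a 5.8-fold lower number from compound 2 to compound 4 (0.76 log units; beyond the scatter)), although these last two steps also change the branching of the butyl chain and so do not isolate the amide. The data at hand offer no explanation for this gain.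

From the compounds shown here alone, how much of it rests on the carbonyl and how much on the amine of the entering group remains open. An acetyl group on this nitrogen would separate the two, and a 3-aminopropanoyl group would test a longer chain.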